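This account rests on a few compounds, and the source may have more. Where it says the series, first, only, none or still open, it means among the compounds named here.

Within the data shown here, compound 2 `COc1cc(NC(=O)Nc2cc(Nc3cc(Br)ccc3OC)ncn2)cc(OC)c1` stands highest of the two numbers so far in a functional assay on NCI-H520 cells (Homo sapiens) for inhibition, read by MTT assay, with a stated time of 48 h, tested at 10 uM (on this read-out lower numbers stand for less inhibition and higher numbers for more inhibition at the one concentration tested (going by the name of the read-out)), where compound 2 gives 43.5%. Compound 1 `CCc1cccc(Nc2cc(NC(=O)Nc3cc(OC)cc(OC)c3)ncn2)c1` gives 23% in this assay, and the step of a number 20.5 percentage points higher from compound 1 to compound 2 (beyond the scatter) shows that the group on this nitrogen can shift the read-out. Compound 3 `COc1cc(NC(=O)Nc2cc(Nc3ccc(OC)c(I)c3)ncn2)cc(OC)c1` differs from compound 2 by 3-iodo-4-methoxyphenyl in place of 5-bromo-2-methoxyphenyl on a nitrogen on an aromatic ring. Among the measured compounds shown here, only that one step bears on this change, and it concerns a different group entering, so no direction beyond the scatter follows from it. Compound 3 is therefore expected to give 40%, within a range from 20% to 60%, which means an expected step of a number 3.5 percentage points lower from compound 2 to compound 3 (within the scatter).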

Compound 3, a percentage reported as inhibition, at one concentration (the size of the read-out at that concentration, not a potency): 46.5%
Compound 3: middle estimate off by 6.5 percentage points, on the low side; the measured number falls inside the stated range.
By their numbers in this assay, from the lowest: compound 1; then compounds 2 and 3 (each within the scatter of the next).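

In this assay the exchange at this nitrogen gives no separable change (a number 3 percentage points higher from compound 2 to compound 3 (within the scatter)), even though the halogen differs and the two group names place their substituents differently. The gain over 3-ethylphenyl also appears with this second halogen-bearing methoxyphenyl group (a number 23.5 percentage points higher from compound 1 to compound 3 (beyond the scatter)), so among these compounds it is not unique to 5-bromo-2-methoxyphenyl. No measurement here gives a reason for these numbers. The compounds shown leave open whether the halogen or the methoxy group matters on its own, and how a phenyl ring carrying an amine or a carboxylic acid would read at this nitrogen.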